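This account rests on a few compounds, and the source may have more. Where it says the series, first, only, none or still open, it means among the compounds named here.

Measured compounds:
compound 1, `CC(=O)c1ccc(NC(=O)C(CC(C)C)N(C(=O)c2ccccc2)S(=O)(=O)c2ccc(C)cc2)cc1`: in a functional assay for inhibition, read by spectrophotometry, with a stated time of 20 min, tested at 1 mg/mL (a lower number here means a weaker effect, a higher number a stronger effect of the compound at the concentration tested), compound 1 gives 54%
compound 2, `CC(=O)c1ccc(NC(=O)CN(C(=O)c2ccccc2)S(=O)(=O)c2ccc([N+](=O)[O-])cc2)cc1`: in this assay compound 2 gives 20.6%

For the measured compounds named here, compound 2 stands lowest of the two numbers so far. Going by the values given here, its nearest neighbour is compound 1, whose read-out is higher by a gap beyond the usual scatter; the two compounds differ in more than one place, so no single step can be drawn from one to the other, and the pair only shows that the compound carrying the isobutyl group and the methyl on the sulfonyl ring sits higher.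

Compound 3, `CC(=O)c1ccc(NC(=O)C(CC(C)C)N(C(=O)c2ccccc2)S(=O)(=O)c2ccc([N+](=O)[O-])cc2)cc1`, is not yet measured. It differs from compound 2 by one change: isobutyl in place of hydrogen on a saturated chain carbon bound to an amide-type nitrogen and a carbonyl carbon. Among the compounds with values here, no measured pair isolates this change; the only guidance is that compound 1, which carries the same isobutyl group, gives 54% while compound 2 gives 20.6%.

On that basis the step of a number 19.4 percentage points higher from compound 2 to compound 3 (beyond the scatter) is expected to be upward and larger than the scatter, though its size is uncertain. The value of compound 3 in this assay is estimated at 40%, with a range from 22% to 60%.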

Compound 3, a percentage reported as inhibition, at one concentration (the size of the read-out at that concentration, not a potency): 45%
Compound 3: the middle estimate sits 5 percentage points below what was measured, within the range that was stated.
By their numbers in this assay, from the lowest: compound 2; then compounds 3 and 1 (each within the scatter of the next).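

In this assay, for the compounds shown here, isobutyl in place of hydrogen on a saturated chain carbon bound to an amide-type nitrogen and a carbonyl carbon can now be read as a single change, with nothing else altered: it gives a number 24.4 percentage points higher from compound 2 to compound 3 (beyond the scatter) and so raises the read-out at this position in the one pair available. Nitro in place of methyl on an aromatic carbon, with the isobutyl group kept, gives a number 9 percentage points lower from compound 1 to compound 3 (within the scatter) and thus no difference that can be told from the scatter, so of the two single changes only the isobutyl step stands out. No measurement that could explain either step is available for this series.

From the compounds shown here alone, at the chain carbon only hydrogen and isobutyl are covered, so the effect of a longer chain, a benzyl group or a carboxylic acid there remains open. Going by these compounds, at the aromatic carbon only methyl and nitro are covered, so an amine or a methoxy group there also remains open, and each read-out shows only how strong the effect of a compound is at the single concentration tested.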